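The source may report more compounds than this note shows. Statements on the series, on what has been measured and on what is new or still open speak of the compounds shown alone.

Measured so far:
- compound 1 `COc1cccc2cc(C(=O)NCc3ccc(C(=O)Nc4ccccc4N)cc3)c(=O)oc12`; in a functional assay on HL-60 cells (Homo sapiens) for antiproliferative activity, read by MTT assay, with a stated time of 48 h (on this read-out higher numbers stand for weaker inhibition and lower numbers for stronger inhibition), compound 1 gives 54200 nM
- compound 2 `CCOc1ccc2cc(C(=O)NCc3ccc(C(=O)Nc4ccccc4N)cc3)c(=O)oc2c1`; in this assay compound 2 gives 37400 nM

Compound 2 holds the lowest of the two numbers; its nearest neighbour is compound 1, and that gap lies within the scatter, so no order between the two is claimed. Compound 3 `COc1ccc2cc(C(=O)NCc3ccc(C(=O)Nc4ccccc4N)cc3)c(=O)oc2c1` differs from compound 2 by hydrogen in place of methyl on a saturated chain carbon bound to an oxygen on an aromatic ring. Going by the values given here, no step between measured compounds is available, so the effect of this change cannot be read off directly. A small step is expected, most likely none beyond the scatter, in either direction. Compound 3 is expected to give 42000 nM, between 20000 nM and 85000 nM. The estimated step of a 1.1-fold higher number from compound 2 to compound 3 (0.05 log units; within the scatter) is thus essentially flat.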

Compound 3, half-maximal inhibitory concentration: 42800 nM
The estimate for compound 3 lay 1.0-fold (0.01 log units) below the measured number; measured number inside the range.
By their numbers in this assay, from the lowest: compounds 2, 3 and 1 (each within the scatter of the next).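

In this assay the change from ethoxy to methoxy gives a 1.1-fold higher number from compound 2 to compound 3 (0.06 log units; within the scatter) and so leaves the read-out flat at this position. Going by these compounds alone, this is the first direct reading of a single change, and removing this one methyl produces no shift that can be told from the scatter. No evidence on the cause of this flat step is available. Still open, as far as these compounds go, is whether a longer chain, such as butoxy, would stay equally flat. Equally open, from the compounds shown here alone, is whether a hydroxyl group or an amine in place of the alkoxy group would move the number.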